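Adding a chloro group to compound 2

The source may report more compounds than this note shows. Statements on the series, on what has been measured and on what is new or still open speak of the compounds shown alone.

In a functional assay on MDA-MB-435 cells (Homo sapiens) for inhibition, read by sulforhodamine B assay, with a stated time of 48 h (on this read-out lower numbers stand for stronger inhibition of growth and higher numbers for weaker inhibition of growth), compound 1 (`NC(=O)c1cc(Br)ccc1NC(=O)/C=C/c1ccccc1`) gives 231 nM. Compound 2 (`NC(=O)c1cc(I)ccc1NC(=O)/C=C/c1ccccc1`) has no single number, and the entry for compound 2 reads "not determined" (no result reported). Compound 3 (`NC(=O)c1cc(I)ccc1NC(=O)/C=C/c1ccccc1Cl`) is still unmeasured. The structural change is chloro in place of hydrogen on an aromatic carbon, which places chloro in place of hydrogen on an aromatic carbon, turning phenyl to 2-chlorophenyl. Among the measured compounds shown here, no measured step exists to guide the size of this change. For the measured compounds named here, the only number available is that of compound 1 at 231 nM, and no shift beyond the usual scatter from that level is expected in this assay, in either direction. Compound 3 is estimated at 200 nM, with an expected range from 50 nM to 800 nM.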

Compound 3, concentration for 50% growth inhibition: 234 nM
Compound 3: middle estimate off by 1.2-fold (0.07 log units), on the low side; the measured number falls inside the stated range.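

No new step can be read from compound 2 to compound 3, so this result gives no size for the change. On these data alone, what phenyl to 2-chlorophenyl does in this assay stays open, and no evidence at hand bears on the result.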